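This account rests on a few compounds, and the source may have more. Where it says the series, first, only, none or still open, it means among the compounds named here.

Of the compounds shown here, two built on a shared core have been measured so far. Tested in a functional assay on PC-3 cells (Homo sapiens) for inhibition, read by MTT assay, with a stated time of 48 h (on this read-out higher numbers stand for weaker inhibition and lower numbers for stronger inhibition), compound 1 (`COc1ccc(-c2coc3cc(OCCCBr)ccc3c2=O)cc1`) gives 62600 nM and compound 2 (`COc1ccc(-c2coc3cc(OCCCSC(=S)N4CCN(C(C)=O)CC4)ccc3c2=O)cc1`) gives 4310 nM as its reading. Compound 2 therefore holds the lower of the two numbers, which means the stronger inhibition, and its gap to compound 1 lies beyond the usual scatter of repeated measurements.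

The next compound, compound 3 (`COc1ccc(-c2coc3cc(OCCCSC(=S)N4CCCC4)ccc3c2=O)cc1`), differs from compound 2 in one group: pyrrolidin-1-yl stands in place of 4-acetylpiperazin-1-yl on a thiocarbonyl carbon (pyrrolidin-1-yl in place of 4-acetylpiperazin-1-yl on a thiocarbonyl carbon). For the measured compounds named here, no pair of measured compounds shows what a swap at this place does, so the data offer no direction to lean on. The expectation simply starts from compound 2 at 4310 nM as its anchor. A small weakening that stays within the scatter is expected, estimated as a 1.4-fold higher number from compound 2 to compound 3 (0.14 log units; within the scatter) for this swap. For compound 3 the estimated value is 6000 nM with an expected range from 1500 nM to 24000 nM in this measurement.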

Compound 3, half-maximal inhibitory concentration: 19400 nM
Compound 3: the middle estimate sits 3.2-fold (0.51 log units) below what was measured; low and high end bracket the measured number.
By their numbers in this assay, from the lowest: compound 2; then compound 3; then compound 1.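

Swapping the ring on the thiocarbonyl carbon clearly matters in this assay: pyrrolidin-1-yl in place of 4-acetylpiperazin-1-yl gives a 4.5-fold higher number from compound 2 to compound 3 (0.65 log units; beyond the scatter) and so loses part of the inhibition seen with the larger group. Yet replacing the bromine atom on the saturated chain carbon with the group carrying pyrrolidin-1-yl still gives a 3.2-fold lower number from compound 1 to compound 3 (0.51 log units; beyond the scatter), so the lower reading relative to compound 1 does not rest on the 4-acetylpiperazin-1-yl group alone. Nothing measured here gives a reason for either step.

The swap changes the ring size, the second ring nitrogen and the acetyl group all at once, so the compounds shown cannot say which of these accounts for the difference; a piperidine ring, a morpholine ring or a piperazine ring without the acetyl group would begin to separate them. Also open, on these data alone, is how a longer chain in place of the present one would behave with either ring on the thiocarbonyl carbon.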